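The source may report more compounds than this note shows. Statements on the series, on what has been measured and on what is new or still open speak of the compounds shown alone.

Measured in a functional assay on MCF7 cells (Homo sapiens) for inhibition, read by XTT assay, with a stated time of 48 h; a higher number here means a weaker inhibitor, a lower number a stronger inhibitor:
- compound 1 `CCC(/C=C(\COC(C)=O)C(=O)c1ccc(OC)cc1)CC`: 13700 nM
- compound 2 `CCC(/C=C(\COC(=O)c1ccccc1)C(=O)c1ccc(OC)cc1)CC`: 28000 nM
- compound 3 `CCC(/C=C(\CCOC(C)=O)C(=O)c1ccc(OC)cc1)CC`: > 100000 nM

Compound 3 gives > 100000 nM, which is a limit of the assay and not a number. Its steps from the other two compounds are beyond the scatter, so it is the weakest of the three in this assay.

Compound 4 `COc1ccc(C(=O)/C(=C/c2ccc(Cl)cc2)CCOC(C)=O)cc1` differs from compound 3 at a single place: 4-chlorophenyl in place of pentan-3-yl on a double-bonded chain carbon bound to a double-bonded chain carbon. There, 4-chlorophenyl stands in place of pentan-3-yl on a double-bonded chain carbon bound to a double-bonded chain carbon.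

Among the compounds with values here, no measured step changes that place. All three concern the other arm: a 2.0-fold higher number from compound 1 to compound 2 (0.31 log units; beyond the scatter), an at least 7.2-fold higher number from compound 1 to compound 3 (0.86 log units; beyond the scatter) and an at least 3.5-fold higher number from compound 2 to compound 3 (0.55 log units; beyond the scatter). Within the data shown here, compound 4 keeps the acetoxymethyl of compound 3, and the two steps into compound 3 therefore give the only guidance. On these data alone, they point to a weak compound, and the size of the new change remains open. A small move toward a lower number is expected, though a result at the limit again would be no surprise.

The expected change is an at least 1.6-fold lower number from compound 3 to compound 4 (0.22 log units; that floor lies within the scatter).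

For compound 4 the estimated value is 60000 nM, with an expected range from 20000 nM to 150000 nM.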

Compound 4, half-maximal inhibitory concentration: > 100000 nM
Compound 4: no number, only a limit; the forecaster's own chance of this, stated with the estimate: 45%; middle value at least 1.6-fold (0.22 log units) away from the limit.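

In this assay compound 4 gives > 100000 nM, which is a limit of the assay and not a number. Compound 3 stands at the same limit, so no step between compound 3 and compound 4 can be read: the limit of > 100000 nM in this assay, at which 2 of the 4 values shown sit.

The compounds shown leave open whether 4-chlorophenyl in place of pentan-3-yl changes the inhibition at all.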